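The source may hold more compounds than are shown below. What is called first, only, known or untested is meant among the compounds shown, and "the series" means these compounds.

In a functional assay on HepG2 cells (Homo sapiens) for antiproliferative activity, read by CCK-8 assay, with a stated time of 48 h (a lower number here means a stronger inhibitor, a higher number a weaker inhibitor), compound 1 `COc1ccc(/C=C\c2cc(OC)c(OC)c(OC)c2)cc1OCc1ccc(CN2C[C@H](O)C[C@@H]2C(=O)O)cc1` gives > 10000 nM, which is a limit and not a number. Compound 2 `COc1ccc(/C=C\c2cc(OC)c(OC)c(OC)c2)cc1OCc1ccc(CN2CCCC[C@H]2C(=O)O)cc1` gives > 10000 nM in this assay, again a limit. Compound 3 `COc1ccc(/C=C\c2cc(OC)c(OC)c(OC)c2)cc1OCc1ccc(CN2CCCC[C@@H]2C(=O)O)cc1` gives > 10000 nM, also a limit, so compound 3 has no number of its own in this series.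

Compound 4 `COc1ccc(/C=C\c2cc(OC)c(OC)c(OC)c2)cc1OCc1ccc(CN2CCCCC2C(=O)O)cc1` is the next structure to read against compound 3: the two compounds have the same atoms and bonds; at least one stereo element is drawn with a configuration in one of them and without one in the other: 1 of 2 stereo elements differ; a stereocentre at a saturated ring carbon is drawn R in compound 3 and without a configuration in compound 4. The change in the ring and its substituent, seen in a step that the two limits leave unreadable from compound 1 to compound 2 and a step that the two limits leave unreadable from compound 1 to compound 3, does not occur here, so those steps bear on it only weakly. The closest measured step is a step that the two limits leave unreadable from compound 2 to compound 3, which touches only the same stereocentre, as stated by the fact that compounds 2 and 3 differ only in the configuration as drawn. Its size cannot be read because of the limit of > 10000 nM in this assay, at which 3 of the 3 values shown sit.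

Neither drawn configuration, in compound 2 or compound 3, gave a number, so no direction can be assigned. The expectation rests on compound 3 at > 10000 nM, a limit. The expected step, a step that the limit leaves unreadable from compound 3 to compound 4, is none beyond the scatter, and a result reported again as a limit is the likely outcome. For compound 4 the estimated value is 20000 nM, with an expected range from 10000 nM to 50000 nM.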

Compound 4, half-maximal inhibitory concentration: 3100 nM
Estimate against measurement, compound 4: 6.5-fold (0.81 log units) above; the whole stated range lies above it.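

Among these compounds, with 2-carboxypiperidin-1-yl on the shared core, this assay now gives an at least 3.2-fold lower number from compound 3 to compound 4 (0.50 log units; beyond the scatter) and an at least 3.2-fold lower number from compound 2 to compound 4 (0.50 log units; beyond the scatter), the first steps at this stereocentre with a readable direction. The change from 2-carboxy-4-hydroxypyrrolidin-1-yl also gains a direction, as an at least 3.2-fold lower number from compound 1 to compound 4 (0.50 log units; beyond the scatter), but compounds 2 and 3 go against any reading that credits the ring change alone, since they carry the same 2-carboxypiperidin-1-yl group and remain at a limit. Compound 4 has the same atoms and bonds as compound 3, so this step rests only on how the stereocentre is drawn: the fact that one of compounds 3 and 4 is drawn with a defined configuration and the other without, at the place where they differ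

As far as these compounds go, the steps among compounds 1, 2 and 3 cannot be read, so neither drawn configuration can be ranked against the other, and what compound 4 contains at the undrawn stereocentre stays open. Also open, from the compounds shown here alone, is whether the carboxylic acid is required on the ring, as a methyl ester or a primary amide in its place, or a 2-carboxypyrrolidin-1-yl group without the hydroxyl, would test that part of the structure directly.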